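This account rests on a few compounds, and the source may have more. Where it says the series, first, only, none or still open, it means among the compounds named here.

Measured so far:
Compound 1 `O=C(NCCCCc1ccccc1)c1cccc(C2SCC(=O)N2c2cccc(-c3c[nH]nn3)c2)c1` gives 110 nM in a functional assay on HOS-TE85 cells (Homo sapiens) for inhibition, read by CCK-8 assay, with a stated time of 72 h; on this read-out higher numbers stand for weaker inhibition and lower numbers for stronger inhibition
Compound 2 `COc1c(F)cccc1N1C(=O)CSC1c1cccc(C(=O)NCCCCc2ccccc2)c1` gives 26.2 nM in this assay

Of these two numbers, compound 2 holds the lower, which makes it the stronger inhibitor of the pair. The next compound, compound 3 `COc1ccc(N2C(=O)CSC2c2cccc(C(=O)NCCCCc3ccccc3)c2)c(OC)c1`, has not yet been measured. It carries 2,4-dimethoxyphenyl in place of 3-fluoro-2-methoxyphenyl on an amide-type nitrogen in a ring, a change counted as 2,4-dimethoxyphenyl in place of 3-fluoro-2-methoxyphenyl on an amide-type nitrogen in a ring and the only difference between the two.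

Within the data shown here, one measured step bears on this change: a 4.2-fold lower number from compound 1 to compound 2 (0.62 log units; beyond the scatter) was a modest one, made at the same place. Among the measured compounds shown here, no measured compound carries the 2,4-dimethoxyphenyl group, so the data do not fix a direction. With compound 2 at 26.2 nM as the lower of the two numbers, a step of similar or smaller size is expected in this assay and it leans towards a higher number. The estimated step is a 1.5-fold higher number from compound 2 to compound 3 (0.18 log units; within the scatter). For the measured compounds named here, a step as large as the one between compound 1 and compound 2 remains possible in either direction. For compound 3 the estimated value is 40 nM with an expected range from 12 nM to 130 nM.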

Compound 3, half-maximal inhibitory concentration: 90.4 nM
The estimate for compound 3 lay 2.3-fold (0.35 log units) below the measured number; measured number inside the range.
By their numbers in this assay, from the lowest: compound 2; then compounds 3 and 1 (each within the scatter of the next).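

In this assay, the group on the amide-type nitrogen in the ring matters even when one six-membered aromatic ring of carbon only is exchanged for another, since 2,4-dimethoxyphenyl in place of 3-fluoro-2-methoxyphenyl gives a step beyond the scatter (a 3.5-fold higher number from compound 2 to compound 3 (0.54 log units; beyond the scatter)), so the lower number of compound 2 does not extend to every methoxy-bearing phenyl at this position. The other new step is within the scatter (a 1.2-fold lower number from compound 1 to compound 3 (0.09 log units; within the scatter)), so 2,4-dimethoxyphenyl and the larger group with its five-membered aromatic ring cannot be told apart here, and losing that five-membered ring is not by itself enough to reach the number of compound 2. Nothing in the data gives a reason for this difference between the two methoxy-bearing groups.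

The exchange from compound 2 to compound 3 alters more than one feature of the ring at once, so the shares of the fluorine and of the second methoxy remain unseparated. From the compounds shown here alone, it also remains open how an unsubstituted phenyl, or a ring carrying chlorine or a nitrile in place of the fluorine, would read at this position.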